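This account rests on a few compounds, and the source may have more. Where it says the series, first, only, none or still open, it means among the compounds named here.

In a functional assay on A549 cells (Homo sapiens) for cytotoxicity (on this read-out lower numbers stand for stronger inhibition and higher numbers for weaker inhibition), compound 1 (`O=C1NC(c2ccc(Cl)cc2)CN1S(=O)(=O)c1ccc2c(c1)CCC2`) gives 86300 nM and compound 2 (`O=C1NC(c2ccc(Br)cc2)CN1S(=O)(=O)c1ccc(Cl)cc1`) gives 161000 nM, two numbers within the scatter of each other. Compound 3 (`O=C1NC(c2ccccc2)CN1S(=O)(=O)c1ccc(Cl)cc1`) gives 9470 nM, a number well below that of compound 1 and beyond the scatter. Compound 1 therefore sits with compound 2 at the high end of the three numbers.

Compound 4 (`Cc1ccc(C2CN(S(=O)(=O)c3ccc4c(c3)CCC4)C(=O)N2)cc1`) has not yet been measured. It differs from compound 1 by methyl in place of chloro on an aromatic carbon, para to a large group: methyl in place of chloro on an aromatic carbon.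

Going by the values given here, no measured step exchanges chloro or introduces methyl. Among the compounds with values here, the one step that bears on this change is a 17-fold lower number from compound 2 to compound 3 (1.23 log units; beyond the scatter), hydrogen in place of bromo on an aromatic carbon, which is large and comes from a compound with a different remainder. That step removes the halogen outright, whereas compound 4 still carries a group there, so only a small part of it is expected to carry over. In this assay the expectation is a slight move to a lower number, probably not beyond the scatter. The estimated step runs a 1.4-fold lower number from compound 1 to compound 4 (0.16 log units; within the scatter) and remains small. Compound 4 is estimated at 60000 nM, with an expected range from 20000 nM to 170000 nM.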

Compound 4, half-maximal inhibitory concentration: 99200 nM
Compound 4: the middle estimate sits 1.7-fold (0.22 log units) below what was measured, and the stated range covers the measured number.
By their numbers in this assay, from the lowest: compound 3; then compounds 1, 4 and 2 (each within the scatter of the next).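

In this assay, the exchange of 4-chlorophenyl for 4-methylphenyl gives a 1.1-fold higher number from compound 1 to compound 4 (0.06 log units; within the scatter), so on the core of compound 1 methyl can stand in place of chloro on this aromatic carbon without a readable shift in the number. Going by these compounds alone, this is the first pair in which one group replaces another at this position, rather than hydrogen replacing a halogen, and its small step stands apart from a 17-fold lower number from compound 2 to compound 3 (1.23 log units; beyond the scatter), although that larger step comes from a compound with a different remainder. No measurement at hand accounts for the absence of a shift on going from chloro to methyl.

Open, from the compounds shown here alone, is what hydrogen in this place gives on the core of compound 1, and therefore whether the large step seen from bromo to hydrogen carries over to that remainder or belongs to the remainder shared by compound 2 and compound 3. Also open, going by these compounds, is how a methoxy group, an amine or a carboxylic acid on this aromatic carbon would read in this assay on either remainder.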